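Swapping a Chloro-Styryl Amide for a Triazolyl-Phenyl Amide

The source may report more compounds than this note shows. Statements on the series, on what has been measured and on what is new or still open speak of the compounds shown alone.

Compound 1, `CCCN(CC[C@H]1CC[C@H](NC(=O)/C=C/c2ccc(Cl)cc2)CC1)[C@H]1CCc2nc(N)sc2C1`: 2.5 nM
Compound 2, `CCCN(CC[C@H]1CC[C@H](NC(=O)/C=C/c2cccc(Cl)c2)CC1)[C@H]1CCc2nc(N)sc2C1`: 1.2 nM
Compound 3, `CCCN(CC[C@H]1CC[C@H](NC(=O)c2ccccc2-n2cccn2)CC1)[C@H]1CCc2nc(N)sc2C1`: 2 nM

In an assay on brain for displacement of a labelled ligand from D(3) dopamine receptor (Rattus norvegicus) (a higher number here means a weaker inhibitor, a lower number a stronger inhibitor), compound 1 gives the highest of the three numbers; its nearest neighbour is compound 3, and a 1.3-fold lower number from compound 1 to compound 3 (0.10 log units; within the scatter), while the furthest is compound 2, with a 2.1-fold lower number from compound 1 to compound 2 (0.32 log units; beyond the scatter). Compound 4, `CCCN(CC[C@H]1CC[C@H](NC(=O)c2cccc(-n3cncn3)c2)CC1)[C@H]1CCc2nc(N)sc2C1`, differs from compound 1 by 3-(1H-1,2,4-triazol-1-yl)phenyl in place of 2-(4-chlorophenyl)ethenyl on a carbonyl carbon. The step that bears most on this change is the one where an aromatic ring replaces the chlorophenyl-ethenyl chain on the carbonyl carbon: a 1.3-fold lower number from compound 1 to compound 3 (0.10 log units; within the scatter), and likewise a 1.7-fold higher number from compound 2 to compound 3 (0.22 log units; within the scatter). Such swaps have so far stayed within the scatter, so no step beyond the scatter is expected for a 1.2-fold higher number from compound 1 to compound 4 (0.08 log units; within the scatter). Compound 4 is therefore estimated at 3 nM, with a range of 1 nM to 10 nM.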

Compound 4, inhibition constant: 3 nM
Estimate against measurement, compound 4: no gap at the digits printed; the measured number falls inside the stated range.
By their numbers in this assay, from the lowest: compounds 2, 3, 1 and 4 (each within the scatter of the next, the first and the last beyond it).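

On the carbonyl carbon, 3-(1H-1,2,4-triazol-1-yl)phenyl can replace 2-(4-chlorophenyl)ethenyl in this assay with a 1.2-fold higher number from compound 1 to compound 4 (0.08 log units; within the scatter), so neither the chlorine nor the chain double bond is required for a low number. Exchanging the pyrazolyl-phenyl group for this triazolyl-phenyl group also stays within the scatter, with a 1.5-fold higher number from compound 3 to compound 4 (0.18 log units; within the scatter). Only the 3-chlorophenyl comparison goes beyond the scatter, with a 2.5-fold higher number from compound 2 to compound 4 (0.40 log units; beyond the scatter).

Going by these compounds, whether an amine or a carboxylic acid on this phenyl ring would keep the number low remains open. No measurement shown explains these numbers.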